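The source may hold more compounds than are shown below. What is called first, only, known or untested is meant among the compounds shown, and "the series" means these compounds.

Compounds with measurements in a functional assay on PC-9 cells (Homo sapiens) for inhibition, read by MTT assay, with a stated time of 48 h, tested at 10 uM; a lower number here means less inhibition, a higher number more inhibition at the concentration tested (going by the name of the read-out):

compound 1, `COc1cc(NC(=O)Nc2cc(Nc3cc(Br)ccc3OC)ncn2)cc(OC)c1`, giving 82.5%
compound 2, `COc1cc(Br)ccc1Nc1cc(NC(=O)Nc2c(Cl)cccc2Cl)ncn1`, giving 90.5%
compound 3, `Cc1ccc(Nc2cc(NC(=O)Nc3c(Cl)cccc3Cl)ncn2)cc1F`, giving 92%

Compound 1 has the lowest of the three numbers in this assay, but its distance to compound 2 and to compound 3 falls within the usual scatter, so the three measured compounds cannot be told apart on these numbers.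

The compound now to be measured is compound 4, `COc1cc(NC(=O)Nc2cc(Nc3ccc(OC)c(I)c3)ncn2)cc(OC)c1`. It differs from compound 1 in one place: 3-iodo-4-methoxyphenyl in place of 5-bromo-2-methoxyphenyl on a nitrogen on an aromatic ring. Going by the values given here, only one measured step changes the group on that same nitrogen, the one from compound 2 to compound 3, where a different aryl group gave a number 1.5 percentage points higher from compound 2 to compound 3 (within the scatter), a difference that stays within the scatter. Among the compounds with values here, since this is the only step that bears on the change, the expectation is that swapping the aryl group on that nitrogen again leaves this assay roughly where it was, with no step beyond the scatter in either direction.

Compound 4 is therefore expected to give about 84% in this assay, estimated to lie between 72% and 94%, a step of a number 1.5 percentage points higher from compound 1 to compound 4 (within the scatter).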

Compound 4, a percentage reported as inhibition, at one concentration (the size of the read-out at that concentration, not a potency): 47.1%
Beside the measured number, compound 4's estimate is 36.9 percentage points above it; the whole stated range lies above it.
By their numbers in this assay, from the lowest: compound 4; then compounds 1, 2 and 3 (each within the scatter of the next).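

In this assay, the aryl group on this nitrogen proves able to change the result substantially: the swap to 3-iodo-4-methoxyphenyl gives a number 35.4 percentage points lower from compound 1 to compound 4 (beyond the scatter). Going by these compounds alone, the only earlier change on this nitrogen, a number 1.5 percentage points higher from compound 2 to compound 3 (within the scatter), showed no such effect, so the earlier compounds gave no sign that this position could matter so much, although that step involved different aryl groups and a different group elsewhere on the molecule. The two groups in the new step have the same counts of heavy atoms and hydrogen-bond acceptors, so those counts do not separate them, and no measurement here explains the drop.

On these data alone, this step changes the halogen and the placement of both substituents at once, so the contribution of each remains open. As far as these compounds go, a 3-bromo-4-methoxyphenyl group would help separate them, while the effect of an amine on this ring also remains unknown.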